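The source may hold more compounds than are shown below. What is called first, only, known or untested is meant among the compounds shown, and "the series" means these compounds.

Measured so far in an assay on isolated protein for inhibition of ATP-dependent RNA helicase DDX3X (Homo sapiens), read by FRET, with stated times of 30 s and 40 min; a higher number here means a weaker inhibitor, a lower number a stronger inhibitor:
compound 1 `CCCCc1cn(-c2ccc(NC(=O)Nc3cc(OC4CCCC4)ccc3C)cc2)nn1` — 140 nM
compound 2 `CC(C)CC(=O)OCCc1cn(-c2ccc(NC(=O)Nc3ccccc3C(F)(F)F)cc2)nn1` — 400 nM
compound 3 `O=C(Nc1ccc(-n2cc(CCO[C@H]3O[C@@H](CO)[C@H](O)[C@@H]3O)nn2)cc1)Nc1ccccc1C(F)(F)F` — "not active" (no number reported)

Compound 1 holds the lowest of the two numbers reported in this assay. Its nearest neighbour is compound 2, whose number is higher by a margin beyond the usual scatter of repeated measurements. Within the data shown here, compound 3 carries a sugar on the chain of the five-membered aromatic ring and was not active, with no number given, so it adds no step that can be measured. Among the measured compounds shown here, no two of these three compounds differ in a single place, so there is no measured step from which to read off the weight of any one change.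

Compound 4 `CCCCc1cn(-c2ccc(NC(=O)Nc3cc(OCOC)ccc3C)cc2)nn1` is the next compound, yet to be measured in this assay. It differs from compound 1 as follows: methoxymethyl in place of cyclopentyl on an oxygen on an aromatic ring. A smaller group with one hydrogen-bond acceptor thus takes the place of a ring of carbon only.

For the measured compounds named here, with no matching step among the measured compounds, the expectation rests on the shape of the change alone. The step from compound 1 to compound 4 is expected to be a modest one, in the direction of a weaker inhibitor, a 2.5-fold higher number from compound 1 to compound 4 (0.40 log units; beyond the scatter). For compound 4 in this assay the estimate is 350 nM, with a range from 120 nM to 1200 nM.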

Compound 4, half-maximal inhibitory concentration: 820 nM
Estimate against measurement, compound 4: 2.3-fold (0.37 log units) below; the range from low to high includes it.
By their numbers in this assay, from the lowest: compound 1; then compound 2; then compound 4.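

In this assay, among these compounds, the step from cyclopentyl to methoxymethyl on an oxygen on an aromatic ring gives the first measured comparison between two compounds that differ in one place: a 5.9-fold higher number from compound 1 to compound 4 (0.77 log units; beyond the scatter). It shows that the group on this oxygen matters to the number, since the rest of compound 1 stays the same and the step lies beyond the scatter, yet compound 4 still gives a number, 820 nM, rather than a "not active" entry. Nothing shown bears on why the number rises with this change.

The step alters several things at once: the ring of carbon only gives way to an open chain, the heavy-atom count falls, and a hydrogen-bond acceptor enters, so the compounds shown do not separate these features. On these data alone, whether a propyl chain, which has no oxygen, or a tetrahydrofuranyl ring, which keeps a ring and carries an oxygen, would on this same oxygen give a number closer to that of compound 1 or to that of compound 4 remains open.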